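The source may report more compounds than this note shows. Statements on the series, on what has been measured and on what is new or still open speak of the compounds shown alone.

Compound 1 `CCCC1CCCCC1OCCCCCCN1C[C@H](O)[C@@H](O)[C@H](O)[C@H]1CO` is one of three compounds with a number or a limit in an ADME assay on MDBK cells (Bos taurus) for cytotoxicity, read by MTT assay; on this read-out lower numbers stand for higher toxicity in this test and higher numbers for lower toxicity in this test. In this assay compound 1 gives 150000 nM, the lowest of the two numbers shown. Among the compounds with values here, compound 2 `OC[C@@H]1[C@@H](O)[C@H](O)[C@@H](O)CN1CCCCCCOC1CCCCC1C1CCCCC1` gives 200000 nM in this assay, and the step of a 1.3-fold higher number from compound 1 to compound 2 (0.12 log units; within the scatter) is the only measured step between compounds that differ in one place. Compound 3 `OC[C@@H]1[C@@H](O)[C@H](O)[C@@H](O)CN1CCCCCCOc1cccc(C(F)(F)F)c1` gives > 500000 nM in this assay, which is a limit of the assay and not a number. Compound 4 `OC[C@@H]1[C@@H](O)[C@H](O)[C@@H](O)CN1CCCCCCOc1c(F)cc(F)cc1F` differs from compound 1 as follows: a group of 9 heavy atoms (6 carbon, 3 fluorine; one six-membered aromatic ring of carbon only) in place of a group of 9 heavy atoms (9 carbon; one six-membered non-aromatic ring of carbon only), on an oxygen on a saturated carbon. Within the data shown here, no measured step carries this kind of change; the step from compound 1 to compound 2 alters only a saturated ring and stays within the scatter, so it says little here. Compound 3, which like compound 4 bears an aromatic ring on the ether oxygen, sits at the limit of > 500000 nM in this assay, at which 1 of the 3 values shown sits, and that is the closest guide. The number for compound 4 is therefore expected to move upward, by an estimated 2.3-fold higher number from compound 1 to compound 4 (0.37 log units; beyond the scatter), with a fair chance that only a limit is reported. Compound 4 is estimated at 350000 nM, within a range from 150000 nM to 800000 nM.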

Compound 4, half-maximal cytotoxic concentration: > 500000 nM
Compound 4: no number, only a limit; the forecaster's own chance of this, stated with the estimate: 45%; middle value at least 1.4-fold (0.15 log units) from the limit.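

Putting 2,4,6-trifluorophenyl on the oxygen in place of the saturated ring group gives an at least 3.3-fold higher number from compound 1 to compound 4 (0.52 log units; beyond the scatter), so this change, unlike the earlier swap on a saturated ring, moves the read-out in this assay beyond the scatter, towards lower toxicity in this test. From the compounds shown here alone, compound 4 gives only a limit of the assay, so the full size of the step stays unknown. Compound 3, with a trifluoromethyl-bearing aromatic ring on the same oxygen, also ends at a limit, so both aromatic compounds shown stop at the same point: the limit of > 500000 nM in this assay, at which 2 of the 4 values shown sit.

These two limits leave the two aromatic groups unranked against each other. Going by these compounds, it also stays open whether an unsubstituted phenyl, or an aromatic ring carrying an amine or a carboxylic acid, would reach the same limit, and what a longer chain would do.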